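The source may report more compounds than this note shows. Statements on the series, on what has been measured and on what is new or still open speak of the compounds shown alone.

Three compounds share one core and differ only in the aryl group attached to a carbon with a double bond to nitrogen. Compound 1 `COc1cc2c(Oc3ccc(NC(=O)N/N=C/c4ccc(Cl)cc4Cl)cc3F)ccnc2cc1OCCCN1CCCCC1` carries a 2,4-dichlorophenyl there, compound 2 `COc1cc2c(Oc3ccc(NC(=O)N/N=C/c4ccc(O)cc4)cc3F)ccnc2cc1OCCCN1CCCCC1` a 4-hydroxyphenyl, and compound 3 `C=CCc1cccc(/C=N/NC(=O)Nc2ccc(Oc3ccnc4cc(OCCCN5CCCCC5)c(OC)cc34)c(F)c2)c1OC` a 3-allyl-2-methoxyphenyl. In a functional assay on MDA-MB-231 cells (Homo sapiens) for cytotoxicity, read by MTT assay, with a stated time of 72 h (on this read-out higher numbers stand for weaker inhibition and lower numbers for stronger inhibition), compound 1 gives 750 nM, compound 2 gives 790 nM, and compound 3 gives 790 nM. Compound 3 thus stands level with compound 2, the two together holding the highest numbers of the three, while the step of a 1.1-fold higher number from compound 1 to compound 3 (0.02 log units; within the scatter) is as small as the steps of a 1.1-fold higher number from compound 1 to compound 2 (0.02 log units; within the scatter) and no change at the digits printed from compound 2 to compound 3 (within the scatter). Compound 4 `COc1cc2c(Oc3ccc(NC(=O)N/N=C/c4cc5ccccc5[nH]4)cc3F)ccnc2cc1OCCCN1CCCCC1` has not been measured; it differs from compound 3 in one place: 1H-indol-2-yl in place of 3-allyl-2-methoxyphenyl on a carbon with a double bond to nitrogen. Among the measured compounds shown here, no measured step involves this group, so the only guide is that every exchange of the aryl group so far left the result in this assay unchanged beyond the scatter. Compound 4 is therefore expected to show no change at the digits printed from compound 3 to compound 4 (within the scatter). The estimated value for compound 4 is 790 nM, within a range from 350 nM to 1800 nM.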

Compound 4, half-maximal inhibitory concentration: 980 nM
Compound 4: middle estimate off by 1.2-fold (0.09 log units), on the low side; low and high end bracket the measured number.
By their numbers in this assay, from the lowest: compounds 1, 2, 3 and 4 (each within the scatter of the next).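

Until now every group at this position was a single six-membered aromatic ring of carbon only, whereas 1H-indol-2-yl brings a five-membered aromatic ring with a hetero atom and a hydrogen-bond donor. Even so, each step in this assay stays within the scatter (a 1.2-fold higher number from compound 3 to compound 4 (0.09 log units; within the scatter); a 1.2-fold higher number from compound 2 to compound 4 (0.09 log units; within the scatter); a 1.3-fold higher number from compound 1 to compound 4 (0.12 log units; within the scatter)). So among these four compounds, the number does not separate one-ring from two-ring aryl groups on the carbon with a double bond to nitrogen, and no further data are at hand to explain this.

On these data alone, all four groups are aromatic, so it remains open whether a cyclohexyl ring or a plain butyl chain here would move the number beyond the scatter. The same question stands for a phenyl ring carrying a carboxylic acid or an amine.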